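Aryl swap on the ring amine: expected inhibition of compound 3

The compounds below may be only part of what the source reports. "The series", "measured", "known", "first", "only" and "open" are said of these compounds alone.

Compound 2 `CCCc1nc(-c2ccccc2)c(CNCCN2CCN(c3ccc(OC)cc3)CC2)o1` gives 51.5% in an assay on HEK293 cells for inhibition of Voltage-dependent T-type calcium channel subunit alpha-1G (Homo sapiens), read by fluorescence, tested at 10 uM; on this read-out lower numbers stand for less inhibition and higher numbers for more inhibition at the one concentration tested (going by the name of the read-out); against compound 1 `CCCc1nc(-c2ccccc2)c(CNCCN2CCN(c3ccccc3Cl)CC2)o1`, which gives 60.1%, it lies within the scatter, as the step of a number 8.6 percentage points lower from compound 1 to compound 2 (within the scatter) shows. Compound 3 `CCCc1nc(-c2ccccc2)c(CNCCN2CCN(c3cccc(F)c3)CC2)o1` differs from compound 2 by 3-fluorophenyl in place of 4-methoxyphenyl on an amine nitrogen in a ring. Going by the values given here, the only measured step that bears on this change is the earlier exchange of the aryl group on the same amine nitrogen in a ring, a number 8.6 percentage points lower from compound 1 to compound 2 (within the scatter), which stayed within the scatter. The expected step is therefore a number 3.5 percentage points higher from compound 2 to compound 3 (within the scatter), nothing beyond the scatter. Compound 3 is estimated at 55%, with a range from 35% to 75%.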

Compound 3, a percentage reported as inhibition, at one concentration (the size of the read-out at that concentration, not a potency): 62.3%
Beside the measured number, compound 3's estimate is 7.3 percentage points below it, and the stated range covers the measured number.
By their numbers in this assay, from the lowest: compounds 2, 1 and 3 (each within the scatter of the next, the first and the last beyond it).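

In this assay, going by these compounds alone, the exchange of aryl groups on the amine nitrogen in a ring now gives a first step beyond the scatter, modest in size: a number 10.8 percentage points higher from compound 2 to compound 3 (beyond the scatter) for 3-fluorophenyl in place of 4-methoxyphenyl. The other exchange at this position, a number 2.2 percentage points higher from compound 1 to compound 3 (within the scatter), leaves 3-fluorophenyl and 2-chlorophenyl unseparated. No evidence on the origin of either step is at hand.

From the compounds shown here alone, whether the position of the fluorine matters stays open, and 2-fluorophenyl or 4-fluorophenyl would test it. Also open, going by these compounds, is how an unsubstituted phenyl or a saturated cyclohexyl group on the same nitrogen would read.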